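The compounds below may be only part of what the source reports. "The series", "measured", "known", "first", "only" and "open" are said of these compounds alone.

Three compounds share one core. Compound 1 `CC1=NC(C)=C([N+](=O)[O-])C(c2ccccn2)/C1=C(\O)OC(C)(C)C` gives 1810000 nM in a functional assay (cardiac atrium) for agonist activity, with Cavia porcellus as the target; a lower number here means that less compound is needed, a higher number that more compound is needed for the effect. Compound 2 `CO/C(O)=C1\C(C)=NC(C)=C([N+](=O)[O-])C1c1cccnc1` gives 70000 nM in this assay. Compound 3 `CC1=NC(C)=C([N+](=O)[O-])C(c2ccncc2)/C1=C(\O)OC1CCCC1` gives 4250 nM in this assay, the lowest of the three numbers; its gaps to compound 2 and to compound 1 both lie beyond the scatter. Compound 4 `CC1=NC(C)=C([N+](=O)[O-])C(c2ccncc2)/C1=C(\O)OC(C)C` differs from compound 3 in one place: isopropyl in place of cyclopentyl on an oxygen on an unsaturated carbon. Among the measured compounds shown here, no two measured compounds differ in only one place, so the size of such a step cannot be read from them. The step of a 1.9-fold higher number from compound 3 to compound 4 (0.27 log units; within the scatter) is expected to be a modest rise in the number, possibly not beyond the scatter. For compound 4 the estimate is 8000 nM, with a range from 2000 nM to 30000 nM.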

Compound 4, half-maximal effective concentration: 8050 nM
Estimate against measurement, compound 4: 1.0-fold (0.00 log units) below; the measured number falls inside the stated range.
By their numbers in this assay, from the lowest: compounds 3 and 4 (each within the scatter of the next); then compound 2; then compound 1.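

Among the compounds shown here, this pair gives the first comparison in which only one place differs: in this assay, isopropyl in place of cyclopentyl on an oxygen on an unsaturated carbon gives a 1.9-fold higher number from compound 3 to compound 4 (0.28 log units; within the scatter). At this place, the five-membered ring can thus give way to an open group of 3 heavy atoms without a difference beyond the scatter. No evidence shown bears on this result. As far as these compounds go, whether a longer chain, an amine or a carboxylic acid on this oxygen would give a similar number stays open. The steps to compound 1 and compound 2 cannot be read.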